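The compounds below may be only part of what the source reports. "The series", "measured", "known", "first", "only" and "open" are said of these compounds alone.

Measured so far:
Compound 1, `Cn1nc(COc2cc(F)cc(F)c2)c2c1CCN(C(=O)Nc1ccc(Br)cc1)C2`: in an assay on cells for inhibition of Pendrin (Mus musculus), read by fluorescence, with a stated time of 10 min (on this read-out higher numbers stand for weaker inhibition and lower numbers for stronger inhibition), compound 1 gives 3300 nM.
Compound 2, `Cn1nc(COc2cc(F)cc(F)c2)c2c1CCN(C(=S)NC1CCCCC1)C2`: in this assay compound 2 gives only > 10000 nM, which is a limit of the assay and not a number.

Compound 2 thus stands at the limit of > 10000 nM in this assay, at which 1 of the 2 values shown sits, and its position on the numbers is known only as that limit. Among the measured compounds shown here, the one measured step, an at least 3.0-fold higher number from compound 1 to compound 2 (0.48 log units; beyond the scatter), is the sole guide to this series so far.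

Compound 3, `CCN(CC)S(=O)(=O)N1CCc2c(c(COc3cc(F)cc(F)c3)nn2C)C1`, differs from compound 2 in one place: a group of 8 heavy atoms (4 carbon, 1 nitrogen, 2 oxygen, 1 sulfur; no ring) in place of a group of 9 heavy atoms (7 carbon, 1 nitrogen, 1 sulfur; one six-membered non-aromatic ring of carbon only), on an amine nitrogen in a ring. For the measured compounds named here, no measured step covers a diethylsulfamoyl on this ring nitrogen. Going by the values given here, the step of an at least 3.0-fold higher number from compound 1 to compound 2 (0.48 log units; beyond the scatter) concerns a different exchange and shows only that the number for compound 2 moved beyond what this assay reports. For the change from compound 2 to compound 3 no direction can be read from the data, so the expected step in this assay is written as a step that the limit leaves unreadable from compound 2 to compound 3 with wide uncertainty. Compound 3 is therefore estimated at 15000 nM in this assay, within a range from 3000 nM to 60000 nM, with a fair chance that the assay again returns only a limit.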

Compound 3, half-maximal inhibitory concentration: > 10000 nM
Compound 3 was reported as a limit (the forecaster's own chance of this, stated with the estimate: 60%); the middle value is on the limit's open side.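

In this assay compound 3 gives > 10000 nM, which is a limit of the assay and not a number. Diethylsulfamoyl in place of (4-bromophenyl)carbamoyl on the amine nitrogen in a ring gives an at least 3.0-fold higher number from compound 1 to compound 3 (0.48 log units; beyond the scatter), so a second exchange at this position, now with an entering group that has no ring and 0 hydrogen-bond donors, also gives no readable value. The step between compound 2 and compound 3 cannot be read, and the two can only be placed together at the limit: the limit of > 10000 nM in this assay, at which 2 of the 3 values shown sit.

Going by these compounds, how far compound 2 and compound 3 lie past the limit, and whether they differ from each other at all, stays open. Also open, on these data alone, is which part of the (4-bromophenyl)carbamoyl group goes with the measured number of compound 1, and whether a phenylcarbamoyl group without the bromine, a benzyl group or a pyridine ring on this ring nitrogen would return a number or another limit.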